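The source may report more compounds than this note shows. Statements on the series, on what has been measured and on what is new or still open speak of the compounds shown alone.

Two close relatives, compound 1 `Cc1ccc([C@H](C)NC(=O)Cn2nnc3ccccc3c2=O)cc1` and compound 2 `C[C@@H](NC(=O)Cn1nnc2ccccc2c1=O)c1ccccc1`, have been tested in an ADME assay on microsomes from liver (Homo sapiens) for metabolic stability; on this read-out higher numbers stand for fast clearance and lower numbers for slow clearance. Compound 1 gives < 9.9 mL/min/kg, which is a limit of the assay and not a number. Compound 2 gives < 9.9 mL/min/kg, which is also a limit. Neither compound therefore has an exact figure.

Compound 3 `Cc1ccc([C@H](C)NC(=O)Cn2nnc3ccccc3c2=O)nc1` keeps the core of compound 1 and changes one group: 5-methylpyridin-2-yl in place of 4-methylphenyl on a saturated chain carbon bound to an amide-type nitrogen and a saturated chain carbon. Here, 5-methylpyridin-2-yl stands in place of 4-methylphenyl on a saturated chain carbon bound to an amide-type nitrogen and a saturated chain carbon. Within the data shown here, no measured pair shows what this swap does. Among the measured compounds shown here, the only guide is compound 1, which shares (the limit of < 9.9 mL/min/kg in this assay, at which 2 of the 2 values shown sit). No change beyond the scatter is therefore expected in either direction, and the result may again be a limit. The estimated change is a step that the limit leaves unreadable from compound 1 to compound 3. For compound 3, the expected clearance is 7 mL/min/kg, with an estimated range from 4 mL/min/kg to 13 mL/min/kg.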

Compound 3, clearance: < 9.9 mL/min/kg
Compound 3: no number, only a limit (the forecaster's own chance of this, stated with the estimate: 75%); the middle value does not contradict the limit.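

No step can be read between compound 1 and compound 3 in this assay: both results are limits of the assay, not numbers. Whether 5-methylpyridin-2-yl in place of 4-methylphenyl changes clearance at all stays open, and the compounds shown share one result: the limit of < 9.9 mL/min/kg in this assay, at which 3 of the 3 values shown sit.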